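A few compounds are considered here, and "the series" means these few. Any claim that something is new, unique, unknown or untested is made for them only; others in the source may bear on it.

Working notes on the series. Compound 1 `CC[C@H](c1ccc(O)cc1)[C@@H](CC)c1ccc(C(=O)CCl)cc1` gives 0.5 h in an ADME assay for pharmacokinetics; on this read-out higher numbers stand for a longer-lived compound and lower numbers for a shorter-lived compound. Compound 2 `CC[C@H](c1ccc(O)cc1)[C@@H](CC)c1ccc(OCC(=O)CBr)cc1` in this assay returns only a limit, < 0.5 h, and no number. Compound 3 `CC[C@H](c1ccc(O)cc1)[C@@H](CC)c1ccc(CCl)cc1` gives 1.3 h in this assay. The measured steps run a 2.6-fold higher number from compound 1 to compound 3 (0.41 log units; beyond the scatter) and an at least 2.6-fold higher number from compound 2 to compound 3 (0.41 log units; beyond the scatter), while a number no higher from compound 1 to compound 2 (the limit leaves the size open). Compound 2 therefore sits at the floor of the three values shown, at the limit of < 0.5 h in this assay, at which 1 of the 3 values shown sits.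

Compound 4 `CC[C@H](c1ccc(O)cc1)[C@@H](CC)c1ccc(CBr)cc1` is not yet measured. The change bromomethyl in place of ((bromomethyl)carbonyl)methoxy on an aromatic carbon: ((bromomethyl)carbonyl)methoxy leaves and bromomethyl enters on an aromatic carbon. The step from compound 2 to compound 3 bears most directly, since it also removes the ((bromomethyl)carbonyl)methoxy group, and it was at least modest and upward. For the measured compounds named here, compound 4 and compound 3 differ only in bromine for chlorine within the small group that enters, and for that pair no step is known; compound 3 stands at 1.3 h. An upward step of at least modest size is expected; the expected step in this assay is an at least 1.6-fold higher number from compound 2 to compound 4 (0.20 log units; that floor lies within the scatter). Compound 4 is estimated at 0.8 h, between 0.4 h and 1.6 h.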

Compound 4, half-life: 2.5 h
For compound 4 the middle estimate is 3.1-fold (0.49 log units) below the measured one, outside the stated range (above it).
By their numbers in this assay, from the lowest: compound 1; then compounds 3 and 4 (each within the scatter of the next).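

In this assay, bromomethyl on this aromatic carbon gives an at least 5.0-fold higher number from compound 2 to compound 4 (0.69 log units; beyond the scatter) and a 5.0-fold higher number from compound 1 to compound 4 (0.70 log units; beyond the scatter), so among these compounds bromine does not go with the lowest read-out when it is carried on bromomethyl rather than on ((bromomethyl)carbonyl)methoxy. Bromo in place of chloro on the saturated chain carbon bound to an aromatic carbon gives a 1.9-fold higher number from compound 3 to compound 4 (0.28 log units; within the scatter), so compound 3 and compound 4 are not told apart in this assay. Compound 2 remains a limit and not a number, so its step gives only a floor: the limit of < 0.5 h in this assay, at which 1 of the 4 values shown sits.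

The compounds shown leave open how far compound 2 really lies from compound 1. They also leave open how this position responds to a group without a halogen, such as an amine, a carboxylic acid or a longer chain.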